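The source may report more compounds than this note shows. Statements on the series, on what has been measured and on what is new or still open speak of the compounds shown alone.

Compound 1 `CC(C)N(Cc1cccc(OCCCCCC(=O)O)c1)C(=O)c1ccc(-c2cccc3ccccc23)cc1`: < 1.3 nM (a limit)
Compound 2 `CC(C)N(Cc1cccc(OCCCCCC(=O)O)c1)C(=O)c1ccc(-c2ccncc2)cc1`: > 26000 nM (a limit)
Compound 3 `CCOC(=O)CCCCCOc1cccc(CN(C(=O)c2ccc(-c3cccc4ccccc34)cc2)C(C)C)c1`: > 26000 nM (a limit)

All three results come from an ADME assay on BJ cells (Homo sapiens) for cytotoxicity, read by CellTiter-Glo and resazurin assay, with a stated time of 72 h (on this read-out lower numbers stand for an effect already at smaller amounts and higher numbers for an effect only at larger amounts of compound), and none of them is an exact number. Compound 3 stands at the limit of > 26000 nM in this assay, at which 2 of the 3 values shown sit.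

Compound 4 `CCOC(=O)CCCCCOc1cccc(CN(C(=O)c2ccc(-c3ccncc3)cc2)C(C)C)c1` differs from compound 3 in one place: pyridin-4-yl in place of naphthalen-1-yl on an aromatic carbon. The change is pyridin-4-yl in place of naphthalen-1-yl on an aromatic carbon, para to a large group.

Among the compounds with values here, two measured steps bear on this. The same exchange gave an at least 20000-fold higher number from compound 1 to compound 2 (4.30 log units; beyond the scatter). The other difference in compound 4, ethyl in place of hydrogen, gave an at least 20000-fold higher number from compound 1 to compound 3 (4.30 log units; beyond the scatter). Both steps are large, both point upward, and compound 4 carries both changes. A large step back down therefore seems unlikely, and no step beyond the scatter is expected in this assay.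

The estimated step is a step that the limit leaves unreadable from compound 3 to compound 4.

For compound 4 the estimated value is 30000 nM, with an expected range from 15000 nM to 60000 nM.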

Compound 4, half-maximal effective concentration: > 26000 nM
Compound 4: a limit, no number (the forecaster's own chance of this, stated with the estimate: 90%); the middle value is on the limit's open side.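

No new step can be read: compound 4, like compound 2 and compound 3, stands at a limit and not at a number. The compounds shown leave open how far apart these three truly lie, and whether either single exchange matters once the other is present.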